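The source may report more compounds than this note shows. Statements on the series, on what has been measured and on what is new or still open speak of the compounds shown alone.

In a functional assay on PC-3 cells (Homo sapiens) for cytotoxicity (on this read-out higher numbers stand for an effect only at larger amounts of compound and lower numbers for an effect already at smaller amounts), compound 1 `CCc1ccc(/C=C/C(O)=C2/C(=O)C(C)=C(OC)C(C)(C)C2=O)cc1` gives 15.1 ug/mL and compound 2 `COC1=C(C)C(=O)/C(=C(O)/C=C/c2cccc3ccccc23)C(=O)C1(C)C` gives 9 ug/mL so these two values lie within the scatter of each other. Compound 3 `COC1=C(C)C(=O)/C(=C(O)/C=C/c2nccs2)C(=O)C1(C)C` differs from compound 1 in one place on the shared core, a double-bonded chain carbon bound to a double-bonded chain carbon, where 1,3-thiazol-2-yl stands in place of 4-ethylphenyl, and 1,3-thiazol-2-yl in place of 4-ethylphenyl on a double-bonded chain carbon bound to a double-bonded chain carbon gives the count. Going by the values given here, no measured pair covers this change, so no step beyond the scatter is expected in this assay and no direction is favoured. The expected step is a 1.1-fold higher number from compound 1 to compound 3 (0.03 log units; within the scatter) on this estimate. Compound 3 is estimated at 16 ug/mL with an expected range from 6 ug/mL to 40 ug/mL in this series.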

Compound 3, concentration for half-maximal effect: 10.8 ug/mL
Estimate against measurement, compound 3: 1.5-fold (0.17 log units) above; low and high end bracket the measured number.
By their numbers in this assay, from the lowest: compounds 2, 3 and 1 (each within the scatter of the next).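

In this assay, 1,3-thiazol-2-yl in place of 4-ethylphenyl on a double-bonded chain carbon bound to a double-bonded chain carbon leaves the number within the scatter (a 1.4-fold lower number from compound 1 to compound 3 (0.15 log units; within the scatter)). At this position, a five-membered aromatic ring with 2 hetero atoms and 2 hydrogen-bond acceptors can therefore replace a six-membered aromatic ring of carbon only without a step beyond the scatter. No evidence on the cause of this result is available. Going by these compounds, whether an amine or a carboxylic acid on the thiazole or phenyl ring would produce such a step remains open.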